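Shortening the chain on the aromatic nitrogen

A few compounds are considered here, and "the series" means these few. Any claim that something is new, unique, unknown or untested is made for them only; others in the source may bear on it.

Compound 2 `CCCCCCCCn1nc(-c2cccnc2)c2ccccc2c1=O` stands highest of the two numbers in an assay on isolated protein (Oryctolagus cuniculus) with Thromboxane-A synthase (Homo sapiens) as the target, tested at 1 uM (on this read-out higher numbers stand for more inhibition at the one concentration tested (going by the name of the read-out) and lower numbers for less inhibition), where compound 2 gives 99%. Compound 1 `CC(C)n1nc(-c2cccnc2)c2ccccc2c1=O` gives 87%. Among the measured compounds shown here, the one measured step, a number 12 percentage points higher from compound 1 to compound 2 (beyond the scatter), bears on the next change: compound 3 `C=CCn1nc(-c2cccnc2)c2ccccc2c1=O` carries vinyl in place of heptyl on a saturated chain carbon bound to an aromatic nitrogen, so the chain is cut back further than in compound 1. Because a number 12 percentage points higher from compound 1 to compound 2 (beyond the scatter) ran upward with the longer chain, a step downward beyond the scatter is expected in this assay, estimated as a number 19 percentage points lower from compound 2 to compound 3 (beyond the scatter). Compound 3 is expected to give 80%, in the range 60% to 95%.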

Compound 3, a percentage reported as inhibition, at one concentration (the size of the read-out at that concentration, not a potency): 70%
Compound 3: middle estimate off by 10 percentage points, on the high side; the measured number falls inside the stated range.
By their numbers in this assay, from the lowest: compound 3; then compound 1; then compound 2.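

At this position, the change from octyl to allyl gives a number 29 percentage points lower from compound 2 to compound 3 (beyond the scatter) in this assay, so the read-out spans more than the first step showed. Allyl in place of isopropyl gives a number 17 percentage points lower from compound 1 to compound 3 (beyond the scatter), so the two short groups are not interchangeable here. No available evidence explains either step.

Still open, as far as these compounds go, is whether a butyl or hexyl chain would fall in order with these three compounds. Also open, from the compounds shown here alone, is how an amine or a carboxylic acid on the chain would read in this assay.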